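Removing the Acetyl from a Pyrazole Amide

A few compounds are considered here, and "the series" means these few. Any claim that something is new, unique, unknown or untested is made for them only; others in the source may bear on it.

Compound 1 `CNC(=O)N1CCCc2ccc(NC(=O)c3cccc(-c4ccccc4)c3)cc21`: 2.83%
Compound 2 `CNC(=O)N1CCCc2ccc(NC(=O)c3cccc(-c4ccn(C(C)=O)n4)c3)cc21`: 27.6%
Compound 3 `CNC(=O)N1CCCc2ccc(NC(=O)c3ccc(-c4ccn(C)n4)cc3)cc21`: 72.2%

These three values come from a functional assay on MV4-11 cells (Homo sapiens) for antiproliferative activity, with a stated time of 6 days, tested at 1.56 uM; a higher number here means a stronger effect of the compound at the concentration tested, a lower number a weaker effect. Compound 2 stands second of the three numbers: compound 1 lies below it, by the step of a number 24.8 percentage points higher from compound 1 to compound 2 (beyond the scatter), while compound 3 lies well above it but differs from compound 2 in more than one place, so only its value can be set beside that of compound 2. Compound 4 `CNC(=O)N1CCCc2ccc(NC(=O)c3cccc(-c4cc[nH]n4)c3)cc21` differs from compound 2 in one place: hydrogen in place of acetyl on an aromatic nitrogen. Within the data shown here, no measured step touches the group on this ring nitrogen; the single one-place step, a number 24.8 percentage points higher from compound 1 to compound 2 (beyond the scatter), exchanges the whole ring and offers only a loose guide. A small step is therefore expected in this assay, a number 7.4 percentage points higher from compound 2 to compound 4 (within the scatter). Compound 4 is estimated at 35%, within 10% to 65%.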

Compound 4, a percentage reported as inhibition, at one concentration (the size of the read-out at that concentration, not a potency): 27.3%
Estimate against measurement, compound 4: 7.7 percentage points above; the range from low to high includes it.
By their numbers in this assay, from the lowest: compound 1; then compounds 4 and 2 (each within the scatter of the next); then compound 3.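

Removing the acetyl from the ring nitrogen gives a number 0.3 percentage points lower from compound 2 to compound 4 (within the scatter) in this assay and so no difference that can be told apart. The unsubstituted 1H-pyrazol-3-yl still stands apart from phenyl, with a number 24.5 percentage points higher from compound 1 to compound 4 (beyond the scatter) and thus no need for the acetyl to hold that difference. No measured evidence is available to explain either step.

The compounds shown leave open what a longer chain, such as propyl, or a chain ending in an amine would do on this ring nitrogen.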